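Pyridin-2-yl for thiophen-3-yl on the shared core

A few compounds are considered here, and "the series" means these few. Any claim that something is new, unique, unknown or untested is made for them only; others in the source may bear on it.

Three compounds of the series have numbers in a functional assay on cardiac atrium (Cavia porcellus); a higher number here means that more compound is needed for the effect, a lower number that less compound is needed. Compound 2 `COC(=O)C1=C(C)NC(C)=C(C(=O)OC)C1c1c(-c2ccsc2)nc2sccn12` gives 1060 nM, the lowest of the three. Compound 1 `CCOC(=O)C1=C(C)NC(C)=C(C(=O)OCC)C1c1c(-c2cc(OC)ccc2OC)nc2sccn12` gives 2630 nM, a higher number than compound 2 by a margin beyond the scatter. Compound 3 `COC(=O)C1=C(C)NC(C)=C(C(=O)OC)C1c1c(-c2ccncc2)nc2sc(C)cn12` gives 7490 nM, the highest number of the set. Compound 2 thus stands as the most potent of the three measured compounds in this assay, and both neighbours differ from it in more than one place, so no single change can be read from the measured pairs.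

Compound 4 `COC(=O)C1=C(C)NC(C)=C(C(=O)OC)C1c1c(-c2ccccn2)nc2sccn12` is not yet measured. Relative to compound 2 the change is pyridin-2-yl in place of thiophen-3-yl on an aromatic carbon.

Among the compounds with values here, no pair of measured compounds differing in one place is available, so the size of the step is not anchored by a measured one. The working expectation is a modest move toward a higher number, possibly no more than the scatter, with the weaker compounds 1 and 3 suggesting that the better number of compound 2 is not easily kept when the aryl group on this carbon changes. The expected step of a 2.1-fold higher number from compound 2 to compound 4 (0.32 log units; beyond the scatter) is therefore a small weakening. For compound 4 the estimate is 2200 nM, with a range from 700 nM to 7000 nM.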

Compound 4, half-maximal effective concentration: 24400 nM
The estimate for compound 4 lay 11-fold (1.04 log units) below the measured number, outside the stated range (above it).
By their numbers in this assay, from the lowest: compound 2; then compound 1; then compound 3; then compound 4.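

In this assay, within the data shown here, the change from thiophen-3-yl to pyridin-2-yl provides the first step that differs in one place, and it is large: a 23-fold higher number from compound 2 to compound 4 (1.36 log units; beyond the scatter). This shows that the aromatic carbon next to the ring nitrogen and next to the ring atom that bears a large group does not accept every aromatic ring equally, even though the two groups have the same counts of hydrogen-bond donors and acceptors and neither carries a net charge. The data at hand offer no measurement that would explain the step, so it stands as an observation only.

Among these compounds, the single step does not separate the move from a five-membered to a six-membered ring from the exchange of sulfur for a ring nitrogen. Phenyl on this carbon would address the first question, while pyridin-3-yl would test whether the location of the nitrogen within the ring matters, and neither group is among the compounds shown.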